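Methoxy Added to the Aryl Piperazine of Compound 1

The source may report more compounds than this note shows. Statements on the series, on what has been measured and on what is new or still open speak of the compounds shown alone.

Measured so far:
Compound 1 `c1ccc(N2CCN(CCCCOc3ccc4c(c3)CCC4)CC2)cc1`: 50%
Compound 2 `c1ccc(N2CCN(CCCCCOc3ccc4c(c3)CCC4)CC2)cc1`: 25%
Compound 3 `Clc1ccc(N2CCN(CCCOc3ccc4c(c3)CCC4)CC2)cc1`: 58%

In a functional assay on the whole organism for inhibition, with Mus musculus as the target, at a dose of 25 mg/kg by the oral route (on this read-out lower numbers stand for less inhibition and higher numbers for more inhibition at the one dose given (going by the name of the read-out)), compound 1 gives 50%, the second highest of the three numbers. Compound 3 gives 58%, a number within the scatter of compound 1, so the two cannot be told apart. Compound 2 gives 25%, a number beyond the scatter below compound 1. Compound 4 `COc1ccccc1N1CCN(CCCCOc2ccc3c(c2)CCC3)CC1` has not yet been tested; it differs from compound 1 in one place: methoxy in place of hydrogen on an aromatic carbon. Among the measured compounds shown here, no measured pair shows the effect of this change, so the expected size of the step in this assay rests only on the three measured numbers: a small step, possibly none beyond the scatter, is expected in either direction. Compound 4 is therefore expected to give about 55%, within 35% to 75%, an expected step of a number 5 percentage points higher from compound 1 to compound 4 (within the scatter).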

Compound 4, a percentage reported as inhibition, in the whole organism at one dose (the size of the read-out at that dose, not a potency): 42%
Compound 4: middle estimate off by 13 percentage points, on the high side, and the stated range covers the measured number.
By their numbers in this assay, from the lowest: compound 2; then compounds 4, 1 and 3 (each within the scatter of the next, the first and the last beyond it).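

Among the compounds shown here, replacing phenyl with 2-methoxyphenyl gives the first comparison in this assay of two compounds that differ in one place, and it reads a number 8 percentage points lower from compound 1 to compound 4 (within the scatter). At this position, ortho to a large group, methoxy therefore leaves a difference that cannot be told from the usual scatter. Nothing measured here bears on the reason for this result. Still open, from the compounds shown here alone, is whether an amine or a carboxylic acid on this same carbon would also stay within the scatter of compound 1. Going by these compounds, whether ethoxy, with its longer chain, would do so is also open.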